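This account rests on a few compounds, and the source may have more. Where it says the series, first, only, none or still open, it means among the compounds named here.

Compound 1, `COc1cccc(/C=C/C(=O)c2sc(Nc3ccc(Cl)cc3)nc2C)c1`: in a functional assay on Bel-7402 cells (Homo sapiens) for cytotoxicity, read by MTT assay (a higher number here means a weaker inhibitor, a lower number a stronger inhibitor), compound 1 gives > 25000 nM, which is a limit of the assay.
Compound 2, `COc1cccc(/C=C/C(=O)c2sc(Nc3ccccc3)nc2C)c1`: in this assay compound 2 gives > 25000 nM, again a limit of the assay.

Compound 2 therefore stands at a limit in this assay, and only a limit is known for it. Among the measured compounds shown here, the one measured step, a step that the two limits leave unreadable from compound 1 to compound 2, cannot be read because of the limit of > 25000 nM in this assay, at which 2 of the 2 values shown sit. Compound 3, `Cc1nc(Nc2ccccc2)sc1C(=O)/C=C/c1ccccc1Cl`, differs from compound 2 by 2-chlorophenyl in place of 3-methoxyphenyl on a double-bonded chain carbon bound to a double-bonded chain carbon. For the measured compounds named here, no measured step bears on this change in a readable way, so the expectation for this assay rests only on where compound 2 sits, and a number at or near the same limit is expected rather than a step beyond the scatter in either direction. Compound 3 is expected to give about 25000 nM, within 6000 nM to 60000 nM. The step expected in this assay for compound 3 is a number no higher from compound 2 to compound 3 (the limit leaves the size open).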

Compound 3, half-maximal inhibitory concentration: > 25000 nM
Compound 3 was reported as a limit (the forecaster's own chance of this, stated with the estimate: 70%); the middle value lies on the limit itself.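

The step from compound 2 to compound 3 cannot be read in this assay, as both values are limits: the limit of > 25000 nM in this assay, at which 3 of the 3 values shown sit.

The compounds shown leave open whether 2-chlorophenyl in place of 3-methoxyphenyl, or hydrogen in place of chloro, makes any difference to the read-out.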